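The source may report more compounds than this note shows. Statements on the series, on what has been measured and on what is new or still open speak of the compounds shown alone.

Two compounds have been measured so far:

compound 1, `COc1ccccc1-c1ncc(-c2nn[nH]n2)c(O)n1` — 0.1 mg/kg
compound 2, `CC(C)Oc1ccccc1-c1ncc(-c2nn[nH]n2)c(O)n1` — 0.04 mg/kg

Both share the same core and differ only in the group carried on an oxygen on an aromatic ring. In a functional assay on the whole organism with Rattus norvegicus as the target (on this read-out lower numbers stand for an effect already at smaller amounts and higher numbers for an effect only at larger amounts of compound), compound 1 gives 0.1 mg/kg, while compound 2 gives 0.04 mg/kg. For the measured compounds named here, the single step between them, a 2.5-fold lower number from compound 1 to compound 2 (0.40 log units; beyond the scatter), is all that is known about varying this group. Compound 2 therefore stands at the lowest number of the two; its nearest neighbour, compound 1, lies a modest distance higher.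

Compound 3, `CCC(C)Oc1ccccc1-c1ncc(-c2nn[nH]n2)c(O)n1`, extends the same chain once more. The change is methyl in place of hydrogen on a saturated chain carbon, two bonds along the chain from an oxygen on an aromatic ring; isopropoxy becomes sec-butoxy. The step of a 2.5-fold lower number from compound 1 to compound 2 (0.40 log units; beyond the scatter) bears on this, since it too enlarged the group on the same oxygen, though by a larger addition than here. With a smaller addition, a smaller effect is expected: a somewhat lower number in this assay, or none beyond the scatter, the expected step being a 1.3-fold lower number from compound 2 to compound 3 (0.12 log units; within the scatter). Compound 3 is accordingly estimated to give about 0.03 mg/kg, within the range 0.012 mg/kg to 0.08 mg/kg.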

Compound 3, dose for 50% inhibition: 0.05 mg/kg
The estimate for compound 3 lay 1.7-fold (0.22 log units) below the measured number, and the stated range covers the measured number.
By their numbers in this assay, from the lowest: compounds 2, 3 and 1 (each within the scatter of the next, the first and the last beyond it).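

Putting a methyl on the chain turns isopropyl into sec-butyl and gives a 1.3-fold higher number from compound 2 to compound 3 (0.10 log units; within the scatter) in this assay, so at this position on the chain the added carbon brings no difference that can be told from repeat measurements. Compared with methyl on the same oxygen, sec-butyl gives a 2.0-fold lower number from compound 1 to compound 3 (0.30 log units; within the scatter), whereas isopropyl gave a 2.5-fold lower number from compound 1 to compound 2 (0.40 log units; beyond the scatter); the first of these does not clear the scatter and the second does, so only compound 1 and compound 2 can be told apart, and the three compounds show no steady gain with each added carbon. Nothing available here explains these numbers.

The compounds shown leave open how a straight butyl chain, a longer chain, a cyclopentyl ring or a chain ending in an amine or a carboxylic acid on this oxygen would read in this assay. They also leave open whether isopropyl and sec-butyl would stay this close if a chlorine or a fluorine were added elsewhere on the shared core.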